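The source may report more compounds than this note shows. Statements on the series, on what has been measured and on what is new or still open speak of the compounds shown alone.

Compound 1 `Cc1ccccc1C(=O)Nc1ncc(-c2ccccc2)n1C` gives in a toxicity assay on THP-1 cells (Homo sapiens) for inhibition; on this read-out higher numbers stand for lower toxicity in this test and lower numbers for higher toxicity in this test > 100000 nM, which is a limit of the test and not a number.
Compound 2 `Cn1c(-c2ccc(Br)cc2)cnc1NC(=O)c1ccc(F)cc1` gives in this assay 46000 nM.
Compound 3 `COc1ccc(-c2cnc(NC(=O)c3ccccc3C)n2C)cc1` gives in this assay > 100000 nM, again a limit of the test rather than a number.

Compound 3 therefore stands at the limit of > 100000 nM in this assay, at which 2 of the 3 values shown sit. Going by the values given here, the single measured step, a step that the two limits leave unreadable from compound 1 to compound 3, is unreadable, so no step of known size bears on the change to compound 4 `COc1ccc(-c2cnc(NC(=O)c3ccc(Cl)cc3)n2C)cc1`, which is 4-chlorophenyl in place of 2-methylphenyl on a carbonyl carbon. Among the compounds with values here, the only point of comparison is compound 2, whose structure carries a halogen on the ring joined to the carbonyl carbon and which alone of the three yields a number instead of a limit. On that basis compound 4 is expected to read at or below the limit, with a step of an at least 1.4-fold lower number from compound 3 to compound 4 (0.15 log units; that floor lies within the scatter) that cannot be sized from a limit. The estimate for compound 4 in this assay is 70000 nM, expected to fall between 25000 nM and 100000 nM.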

Compound 4, half-maximal cytotoxic concentration: > 100000 nM
Compound 4: a limit, no number; the forecaster's own chance of this, stated with the estimate: 45%; at least 1.4-fold (0.15 log units) between middle value and limit.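

In this assay, going by these compounds alone, compound 3 and compound 4 both give limits of the test and not numbers, so no step between them can be read. The compounds shown leave open whether 4-chlorophenyl in place of 2-methylphenyl on a carbonyl carbon changes this read-out at all.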